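The compounds below may be only part of what the source reports. "The series", "measured", "known", "first", "only" and "open" are said of these compounds alone.

Measured so far in a functional assay on MDA-MB-468 cells (Homo sapiens) for inhibition, read by sulforhodamine B assay, with a stated time of 48 h; a lower number here means a stronger inhibitor of growth, a higher number a weaker inhibitor of growth:
compound 1 `O=C(Nc1cccc(-n2cc(-c3ccncc3)c(-c3ccc(Cl)c(O)c3)n2)c1)Nc1ccc(Cl)c(Cl)c1` gives 729 nM;
compound 2 `COc1cc(-c2nn(-c3cccc(NC(=O)Nc4ccc(Cl)c(C(F)(F)F)c4)c3)cc2-c2ccncc2)ccc1Cl` gives 833 nM;
compound 3 `COc1cc(-c2nn(-c3cccc(NC(=O)c4ccccc4)c3)cc2-c2ccncc2)ccc1Cl` gives 349 nM.

Compound 1 has the second highest of these three numbers; against compound 2 it lies within the scatter, against compound 3 beyond it. Compound 4 `COc1cc(-c2nn(-c3cccc(NC(=O)Nc4ccc(Cl)c(Cl)c4)c3)cc2-c2ccncc2)ccc1Cl` is not yet measured; it differs from compound 1 by methyl in place of hydrogen on an oxygen on an aromatic ring. Among the compounds with values here, no measured step covers this change; the only measured step, a 2.4-fold lower number from compound 2 to compound 3 (0.38 log units; beyond the scatter), alters a different part of the molecule. Compound 1 and compound 2 differ in this place and in one further place, and their values sit within the scatter of each other, so the change alone is expected to give a 1.0-fold lower number from compound 1 to compound 4 (0.02 log units; within the scatter), nothing beyond the scatter. Compound 4 is therefore estimated at 700 nM, within 300 nM to 1700 nM.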

Compound 4, concentration for 50% growth inhibition: 567 nM
Beside the measured number, compound 4's estimate is 1.2-fold (0.09 log units) above it; the range from low to high includes it.
By their numbers in this assay, from the lowest: compounds 3, 4, 1 and 2 (each within the scatter of the next, the first and the last beyond it).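

In this assay, turning the hydroxy of the 4-chloro-3-hydroxyphenyl group into methoxy gives a 1.3-fold lower number from compound 1 to compound 4 (0.11 log units; within the scatter), so on this oxygen hydrogen and methyl cannot be told apart. Two changes elsewhere also stay within the scatter: chloro for trifluoromethyl gives a 1.5-fold lower number from compound 2 to compound 4 (0.17 log units; within the scatter), and (3,4-dichlorophenyl)amino for phenyl on the carbonyl carbon gives a 1.6-fold higher number from compound 3 to compound 4 (0.21 log units; within the scatter). Nothing measured here accounts for these results. Still open, going by these compounds, is how a longer chain such as propyl on this oxygen, or an amine in its place, would read in this assay.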